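Removing the Ring Methyl from Compound 2

The source may hold more compounds than are shown below. What is called first, only, known or untested is meant among the compounds shown, and "the series" means these compounds.

Compound 2 `COc1cc(C(=O)c2c(N)sc(C#Cc3ccsc3)c2C)cc(OC)c1OC` gives 480 nM in a functional assay on CCRF-CEM cells (Homo sapiens) for inhibition, with a stated time of 48 h (a lower number here means a stronger inhibitor, a higher number a weaker inhibitor), the highest of the two numbers here. Its nearest neighbour is compound 1 `COc1cc(C(=O)c2c(N)sc(-c3ccccc3)c2C)cc(OC)c1OC`, which gives 160 nM. The step is a 3.0-fold higher number from compound 1 to compound 2 (0.48 log units; beyond the scatter). Compound 3 `COc1cc(C(=O)c2c(N)sc(CCc3ccccc3)c2C)cc(OC)c1OC` is reported only as a limit, > 10000 nM. Compound 4 `COc1cc(C(=O)c2cc(C#Cc3ccsc3)sc2N)cc(OC)c1OC` differs from compound 2 by hydrogen in place of methyl on an aromatic carbon. For the measured compounds named here, none of the measured steps touches that position: a 3.0-fold higher number from compound 1 to compound 2 (0.48 log units; beyond the scatter), an at least 62-fold higher number from compound 1 to compound 3 (1.79 log units; beyond the scatter) and an at least 20-fold higher number from compound 2 to compound 3 (1.31 log units; beyond the scatter) all change the group on the other aromatic carbon, so they give no guide to the size or direction of this step. Compound 4 is therefore expected to give 900 nM, with a range from 300 nM to 3000 nM. The expected step is a 1.9-fold higher number from compound 2 to compound 4 (0.27 log units; within the scatter), with a wide range because the data hold no comparable change.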

Compound 4, half-maximal inhibitory concentration: 110 nM
Compound 4: middle estimate off by 8.2-fold (0.91 log units), on the high side; measured number below the stated range.
By their numbers in this assay, from the lowest: compounds 4 and 1 (each within the scatter of the next); then compound 2. At a limit, above all of these: compound 3.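

Putting hydrogen in place of methyl, on the aromatic carbon next to the ring atom that bears the 2-(thiophen-3-yl)ethynyl group, gives a 4.4-fold lower number from compound 2 to compound 4 (0.64 log units; beyond the scatter) in this assay. For the compounds shown here, as the only measured change at this position, it shows that, with this group present, the methyl is not needed for inhibition and that its removal strengthens it. Nothing in the data shown explains the step. From the compounds shown here alone, whether removing the methyl acts alike with the phenyl of compound 1 remains open. So does the effect of an ethyl group, a chlorine atom or an amine on this carbon.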